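The compounds below may be only part of what the source reports. "The series", "measured", "known", "first", "only" and "open" are said of these compounds alone.

Measured so far in a functional assay on MCF7 cells (Homo sapiens) for cytotoxicity, read by MTT assay, with a stated time of 48 h; on this read-out higher numbers stand for weaker inhibition and lower numbers for stronger inhibition:
Compound 1 (`COc1cc(C#N)ccc1OCc1nnc(-c2ccc(F)cc2)o1`): 10300 nM
Compound 2 (`COc1ccc(-c2nnc(COc3ccc(C#N)c(F)c3)o2)cc1`): 42200 nM

Of these two, compound 2 at 42200 nM stands highest, beyond the scatter from compound 1. Compound 3 (`N#Cc1ccc(OCc2nnc(-c3ccc(Cl)cc3)o2)cc1F`) differs from compound 2 in one place (chloro in place of methoxy on an aromatic carbon), with chloro in place of methoxy on an aromatic carbon. For the measured compounds named here, no measured step isolates this change. In this assay a modest move toward a lower number is expected, resting only on the lower value of compound 1 (10300 nM). The expected size is a 2.1-fold lower number from compound 2 to compound 3 (0.32 log units; beyond the scatter) and it may not clear the scatter. For compound 3 the estimate is 20000 nM with an expected range from 7000 nM to 55000 nM on repeated measurement.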

Compound 3, half-maximal inhibitory concentration: 48300 nM
The estimate for compound 3 lay 2.4-fold (0.38 log units) below the measured number; measured number inside the range.
By their numbers in this assay, from the lowest: compound 1; then compounds 2 and 3 (each within the scatter of the next).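

In this assay, chloro in place of methoxy on an aromatic carbon, para to a large group, gives (a 1.1-fold higher number from compound 2 to compound 3 (0.06 log units; within the scatter)). At this position, therefore, the two groups cannot be told apart on this read-out, and 4-chlorophenyl and 4-methoxyphenyl read alike on this core. Nothing available accounts for this result.

As far as these compounds go, whether an amine or a carboxylic acid at the same place would give a step beyond the scatter remains open. So does whether a longer chain in place of methoxy would do so.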